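Swapping the Aryl Ketone: Fluorophenyl to Chlorophenyl

A few compounds are considered here, and "the series" means these few. Any claim that something is new, unique, unknown or untested is made for them only; others in the source may bear on it.

For the measured compounds named here, compound 1 `CCOC(=O)[C@@H]1/C(=C/C(=O)c2ccc(F)cc2)N=C(C)/C(=C(/O)OCC)[C@H]1c1ccccc1C(F)(F)F` is the one member of this small set with a number in an assay on brain for binding affinity to Voltage-gated L-type calcium channel (Rattus norvegicus); a lower number here means a stronger inhibitor, a higher number a weaker inhibitor: compound 1 gives 117 nM. Compound 2 `CC1=C([N+](=O)[O-])[C@@H](c2ccccc2C(F)(F)F)[C@H](C(=O)c2ccccc2)C(/C=C(\O)c2ccccc2)=N1` reaches only a limit of this assay, > 1000 nM. Compound 3 `CCOC(=O)C1=C(C)N=C(C2=C(O)c3ccccc3CC2)[C@@H](C(=O)OCC)[C@@H]1c1ccccc1C(F)(F)F` also reaches only a limit in this assay, > 1000 nM. The two remaining values thus fall at the limit of > 1000 nM in this assay, at which 2 of the 3 values shown sit, so compound 1 stands alone as the sole numerical anchor.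

Compound 4 `CCOC(=O)[C@@H]1/C(=C/C(=O)c2ccccc2Cl)N=C(C)/C(=C(/O)OCC)[C@H]1c1ccccc1C(F)(F)F` has not yet been measured in this assay. It differs from compound 1 in a single place, (2-chlorophenyl in place of 4-fluorophenyl on a carbonyl carbon), namely 2-chlorophenyl in place of 4-fluorophenyl on a carbonyl carbon whose other neighbour is a double-bonded chain carbon. Going by the values given here, no measured pair in the set shows this kind of exchange, so the size of the step is a matter of expectation only. Compound 4 is expected to remain close to compound 1, with a step of a 1.1-fold lower number from compound 1 to compound 4 (0.03 log units; within the scatter) that is not expected to exceed the usual scatter of this assay in either direction. The estimate for compound 4 in this assay is 110 nM, with a range from 30 nM to 450 nM.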

Compound 4, half-maximal inhibitory concentration: > 1000 nM
Compound 4: a limit, no number; the forecaster's own chance of this, stated with the estimate: 10%; middle value at least 9.0-fold (0.95 log units) away from the limit.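

In this assay, for the compounds shown here, the exchange of 4-fluorophenyl for 2-chlorophenyl on a carbonyl carbon gives an at least 8.5-fold higher number from compound 1 to compound 4 (0.93 log units; beyond the scatter), the first step in the set that can be read, and it shows that this place is not indifferent to the aryl group it carries. Compound 4 gives > 1000 nM, which is a limit of the assay and not a number, so the step has a lower bound but no measured size. With this result, compound 1 remains the only compound with a number: the limit of > 1000 nM in this assay, at which 3 of the 4 values shown sit.

The two aryl groups differ both in the halogen and in where it sits on the ring, and the compounds shown do not separate these two differences. As far as these compounds go, whether a plain phenyl or a pyridyl ring at this place would retain binding also remains open.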